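The source may report more compounds than this note shows. Statements on the series, on what has been measured and on what is new or still open speak of the compounds shown alone.

Measured compounds and values:

compound 1, `CNC(=O)/C=C/c1ccncc1-c1ccc2[nH]ccc2c1`, > 10000 nM
compound 2, `CNC(=O)/C=C/c1ccncc1-c1ccc2ccccc2c1`, 9340 nM
compound 3, `Cn1ncc2cc(-c3cnccc3/C=C/C(=O)O)ccc21`, > 10000 nM

Of the compounds shown here, three have been tested in a functional assay on MCF7 cells (Homo sapiens) for inhibition, read by sulforhodamine B assay, with a stated time of 72 h; a higher number here means a weaker inhibitor of growth, a lower number a stronger inhibitor of growth. For compound 1 the result is a limit of the assay, > 10000 nM, not a number. For compound 3 the result is likewise a limit, > 10000 nM. For the measured compounds named here, compound 2 is the one whose result is a number: in this assay compound 2 gives 9340 nM, and this is the only number among the three values. The other two results, those of compound 1 and compound 3, sit at the limit of > 10000 nM in this assay, at which 2 of the 3 values shown sit. Nothing further can be said of how the three compounds compare, since two of them only reach that limit.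

The next compound, compound 4, has the structure `CN(C)C(=O)/C=C/c1ccncc1-c1ccc2ccccc2c1`. It differs from compound 2 in one place: methyl in place of hydrogen on an amide-type nitrogen. Going by the values given here, no pair of measured compounds shows the effect of this change, so there is no measured step to lean on. The shared core and the rest of the molecule are unchanged. The expectation is that compound 4 behaves much like compound 2, with no step beyond the usual scatter, and the estimated step is a 1.2-fold higher number from compound 2 to compound 4 (0.07 log units; within the scatter). On that basis compound 4 is expected to give about 11000 nM in this assay, within a range from 4000 nM to 30000 nM.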

Compound 4, concentration for 50% growth inhibition: 8190 nM
For compound 4 the middle estimate is 1.3-fold (0.13 log units) above the measured one, and the stated range covers the measured number.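

In this assay, adding one methyl to the amide-type nitrogen, which turns methylcarbamoyl into dimethylcarbamoyl, gives a 1.1-fold lower number from compound 2 to compound 4 (0.06 log units; within the scatter). For the compounds shown here, this is the first measured pair that differs in only one place, and it shows that the amide hydrogen of compound 2 can give way to a methyl without a difference that the assay can separate from ordinary repeat variation. The pair can reveal only so much, however, since both compounds are weak inhibitors of growth and their numbers lie close to where readings stop: the limit of > 10000 nM in this assay, at which 2 of the 4 values shown sit.

As far as these compounds go, what remains open is whether this nitrogen tolerates more than a single methyl, for example a longer chain such as propyl, or a chain ending in an amine or a carboxylic acid, any of which would test this position far more strongly than one added carbon. From the compounds shown here alone, it is also open whether the same methyl would have as little effect on a different core, such as that of compound 1, or whether this result holds only for the core shared by compound 2 and compound 4.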